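A Hydroxy for a Methyl on the Anilino Ring

The source may report more compounds than this note shows. Statements on the series, on what has been measured and on what is new or still open speak of the compounds shown alone.

Compound 1 `CC(C)c1ccc(-c2nc(SCc3cn(CC(=O)NC(=O)Nc4ccccn4)nn3)nc(Nc3cccc(Cl)c3)c2C#N)cc1`: in a functional assay on MGC-803 cells (Homo sapiens) for inhibition, read by MTT assay, with a stated time of 72 h (on this read-out lower numbers stand for stronger inhibition and higher numbers for weaker inhibition), compound 1 gives > 64000 nM, a limit of the assay.
Compound 2 `CC(C)c1ccc(-c2nc(SCc3cn(CC(=O)NC(=O)Nc4ccccn4)nn3)nc(Nc3cccc(C(F)(F)F)c3)c2C#N)cc1`: compound 2 gives > 64000 nM, also a limit.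
Compound 3 `Cc1ccccc1Nc1nc(SCc2cn(CC(=O)NC(=O)Nc3ccccn3)nn2)nc(-c2ccc(C(C)C)cc2)c1C#N`: compound 3 gives 19000 nM.

Among the measured compounds shown here, compound 3 thus stands as the only compound with a number; the other two sit at the limit of > 64000 nM in this assay, at which 2 of the 3 values shown sit. The two measured steps, an at least 3.3-fold lower number from compound 1 to compound 3 (0.52 log units; beyond the scatter) and an at least 3.3-fold lower number from compound 2 to compound 3 (0.52 log units; beyond the scatter), both lead to compound 3. Compound 4 `CC(C)c1ccc(-c2nc(SCc3cn(CC(=O)NC(=O)Nc4ccccn4)nn3)nc(Nc3ccccc3O)c2C#N)cc1` differs from compound 3 by hydroxy in place of methyl on an aromatic carbon. For the measured compounds named here, no measured step exchanges a methyl for a hydroxy, and the two measured steps trade substituents of a different kind, so they give only a loose guide. Compound 4 is therefore expected to stay close, with an estimated step of a 1.6-fold higher number from compound 3 to compound 4 (0.20 log units; within the scatter) in this assay. Compound 4 is estimated at 30000 nM (8000 nM to 64000 nM).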

Compound 4, half-maximal inhibitory concentration: 16400 nM
Beside the measured number, compound 4's estimate is 1.8-fold (0.26 log units) above it; the measured number falls inside the stated range.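

In this assay, methyl and hydroxy cannot be told apart at this place, ortho to a large group, with a 1.2-fold lower number from compound 3 to compound 4 (0.06 log units; within the scatter), so a group with a hydrogen-bond donor serves here as well as one with none. Against the 3-substituted rings, 2-hydroxyphenyl repeats what 2-methylphenyl showed, with an at least 3.9-fold lower number from compound 1 to compound 4 (0.59 log units; beyond the scatter) and an at least 3.9-fold lower number from compound 2 to compound 4 (0.59 log units; beyond the scatter). Those two steps start from limits of the assay, not from numbers: the limit of > 64000 nM in this assay, at which 2 of the 4 values shown sit.

As far as these compounds go, whether an amine or a methoxy at this place would match compound 3 and compound 4 remains open. So does whether hydroxy keeps this standing on the 3-position of the ring.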